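This account rests on a few compounds, and the source may have more. Where it says the series, first, only, none or still open, it means among the compounds named here.

Measured so far:
Compound 1, `COc1ccn2c(-c3ccc(NC(=O)c4ccc([N+](=O)[O-])o4)cc3)cnc2c1`, in a functional assay on AGS cells (Homo sapiens) for antiproliferative activity, read by CCK-8 assay, with a stated time of 72 h (on this read-out lower numbers stand for stronger inhibition and higher numbers for weaker inhibition), compound 1 gives 720 nM.
Compound 2, `COc1ccn2c(-c3ccc(NC(=O)c4ccc([N+](=O)[O-])o4)c(C)c3C(F)(F)F)cnc2c1`, in this assay compound 2 gives 2100 nM.

Of the two numbers, compound 2 gives the higher one; compound 1 gives a lower number, and this gap lies beyond the scatter of repeat measurements.

Compound 3, `COc1ccn2c(-c3ccc(NC(=O)c4ccc([N+](=O)[O-])o4)c(C)c3)cnc2c1`, is not yet measured. It differs from compound 2 by hydrogen in place of trifluoromethyl on an aromatic carbon. Among the compounds with values here, no measured pair separates this single change, so its size can only be judged from the position of compound 2 against compound 1 in this assay: compound 3 keeps the methyl group but loses the trifluoromethyl, so it sits structurally between the two. The expected step in this assay from compound 2 to compound 3 is a move toward a lower number, about a 1.9-fold lower number from compound 2 to compound 3 (0.28 log units; within the scatter), of modest size. Compound 3 is estimated at 1100 nM in this assay, with a range from 500 nM to 2400 nM.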

Compound 3, half-maximal inhibitory concentration: 430 nM
Estimate against measurement, compound 3: 2.6-fold (0.41 log units) above; measured number outside the range, below it.
By their numbers in this assay, from the lowest: compounds 3 and 1 (each within the scatter of the next); then compound 2.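

In this assay the change from trifluoromethyl to hydrogen on this aromatic carbon gives a 4.9-fold lower number from compound 2 to compound 3 (0.69 log units; beyond the scatter) and so ties the high number of compound 2 to the trifluoromethyl group, with the methyl group kept on both sides of the step. Adding that methyl group alone gives a 1.7-fold lower number from compound 1 to compound 3 (0.22 log units; within the scatter) and so shows no readable effect of the methyl group alone in this assay. No measurement on hand accounts for the size of the trifluoromethyl step.

Only hydrogen and trifluoromethyl are shown at this carbon, so it remains open whether a smaller or differently built group such as fluorine, methoxy or an amine would track hydrogen or trifluoromethyl. As far as these compounds go, the trifluoromethyl group is also seen only alongside the methyl group, so its effect without that methyl group stays unknown.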